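The compounds below may be only part of what the source reports. "The series", "measured", "known", "first", "only" and "open" are said of these compounds alone.

Compound 1: `CCCCCCSc1nc(N)nc2c1ncn2/C=C1/CC1(CO)CO` — > 300000 nM
Compound 2: `Nc1nc2c(ncn2/C=C2/CC2(CO)CO)c(=O)[nH]1` — > 300000 nM

Of the compounds shown here, two built on the same core have been tested so far. In an ADME assay on HFF cells (Homo sapiens) for cytotoxicity, with a stated time of 8 days (a lower number here means that less compound is tolerated, a higher number that more compound is tolerated), compound 1 gives > 300000 nM, which is a limit of the assay rather than a measured number. Compound 2 likewise gives > 300000 nM in this assay, again only a limit. Compound 1 therefore stands at the limit of > 300000 nM in this assay, at which 2 of the 2 values shown sit, and the two values show no separation between them at all.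

The next compound, compound 3 `CC(C)Sc1nc(N)nc2c1ncn2/C=C1/CC1(CO)CO`, differs from compound 1 in one place: isopropyl in place of hexyl on a sulfur. Within the data shown here, no measured pair with this kind of change is available to set the size of the step. With both known values sitting at the limit, the step from compound 1 to compound 3 in this assay is expected to be none beyond the scatter, a number no higher from compound 1 to compound 3 (the limit leaves the size open). Compound 3 is accordingly estimated at 300000 nM, within a range from 100000 nM to 1000000 nM, and most likely reported once more only as a limit.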

Compound 3, half-maximal cytotoxic concentration: > 300000 nM
Compound 3 gave a limit, no number; the forecaster's own chance of this, stated with the estimate: 80%; the middle value sits exactly at the limit.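

Compound 3, like compound 1, gives only a limit in this assay, so no step can be read from compound 1 to compound 3: the limit of > 300000 nM in this assay, at which 3 of the 3 values shown sit.

The compounds shown leave open whether isopropyl in place of hexyl on a sulfur makes any difference in this assay.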